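Hydroxyphenyl Replacing Methoxynaphthyl on the Shared Core

The compounds below may be only part of what the source reports. "The series", "measured", "known", "first", "only" and "open" are said of these compounds alone.

The series shares one core; compound 1 is `COc1cc(N2C(N)=C(C#N)C(/C=C/c3ccccc3)C3=C2CC(C)(C)CC3=O)cc(OC)c1OC`, compound 2 is `COc1cc(N2C(N)=C(C#N)C(c3ccc(OC)c4ccccc34)C3=C2CC(C)(C)CC3=O)cc(OC)c1OC` and compound 3 is `COc1cc(N2C(N)=C(C#N)C(c3c(O)ccc4ccccc34)C3=C2CC(C)(C)CC3=O)cc(OC)c1OC`. In a functional assay on Ehrlich cells (Mus musculus) for cytotoxicity, tested at 25 ug/mL (a higher number here means a stronger effect of the compound at the concentration tested, a lower number a weaker effect), compound 1 gives 30%, compound 2 gives 30% and compound 3 gives 10%. Compound 2 thus stands level with compound 1 at the digits given, the two together the highest of the three numbers; its nearest neighbour is compound 1, with no change at the digits printed from compound 1 to compound 2 (within the scatter), and its furthest is compound 3, with a number 20 percentage points lower from compound 2 to compound 3 (beyond the scatter).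

Compound 4 is `COc1cc(N2C(N)=C(C#N)C(c3ccc(O)cc3)C3=C2CC(C)(C)CC3=O)cc(OC)c1OC`, not yet measured. It differs from compound 2 in one place: 4-hydroxyphenyl in place of 4-methoxynaphthalen-1-yl on a saturated ring carbon. Within the data shown here, three measured steps bear on this. The exchange of 2-phenylethenyl for 4-methoxynaphthalen-1-yl brought no change at the digits printed from compound 1 to compound 2 (within the scatter); the exchange for 2-hydroxynaphthalen-1-yl brought a number 20 percentage points lower from compound 1 to compound 3 (beyond the scatter); and within the naphthyl pair a number 20 percentage points lower from compound 2 to compound 3 (beyond the scatter). Among the measured compounds shown here, the only hydroxyl-bearing group so far, in compound 3, sits at the low end of the numbers, while the change from two aromatic rings to one has no precedent in this set. A modest downward step is therefore expected, a number 10 percentage points lower from compound 2 to compound 4 (within the scatter). Compound 4 is estimated at 20%, with a range from 5% to 35%.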

Compound 4, a percentage reported as activity, at one concentration (the size of the read-out at that concentration, not a potency): 20%
Beside the measured number, compound 4's estimate shows no gap at the digits printed; low and high end bracket the measured number.
By their numbers in this assay, from the lowest: compounds 3, 4, 1 and 2 (each within the scatter of the next, the first and the last beyond it).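

In this assay, among these compounds, the saturated ring carbon takes 4-hydroxyphenyl in place of 4-methoxynaphthalen-1-yl with a number 10 percentage points lower from compound 2 to compound 4 (within the scatter) and this is the first sign that one six-membered aromatic ring can stand there in place of two without a step beyond the scatter. The exchange of 2-phenylethenyl for 4-hydroxyphenyl likewise gives a number 10 percentage points lower from compound 1 to compound 4 (within the scatter) and so leaves compound 4 unseparated from either of the two compounds at the top of the numbers. Against the other hydroxyl-bearing group the step is a number 10 percentage points higher from compound 3 to compound 4 (within the scatter) and a hydroxyl alone therefore does not mark out the low end, since compound 3 is the only compound beyond the scatter of any other, and compound 4, which also carries a hydroxyl, goes against such a pattern.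

As far as these compounds go, whether a phenyl ring carrying a methoxy group, an amine or a carboxylic acid at this carbon would separate from compound 4 stays open, and with it the part played by the hydroxyl apart from the ring count. Nothing at hand gives a reason for any of these numbers.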